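The source may hold more compounds than are shown below. What is called first, only, known or untested is meant among the compounds shown, and "the series" means these compounds.

Working notes on the series in an ADME assay on a cell-free system (plasma, Rattus norvegicus); on this read-out lower numbers stand for a smaller free fraction and higher numbers for a larger free fraction.

Three compounds have numbers. Compound 1 `CC(=O)Nc1cc(-c2ccc(N(C)C(=O)c3c(F)cccc3Cl)c(N3CC4CC4C3)c2)n(C2CCC2)n1` gives 0.0004 in this assay. Compound 2 `CC(=O)Nc1cc(-c2cnc(N(C)C(=O)c3c(F)cccc3Cl)c(N3CC4CC4C3)c2)n(C(C)C)n1` gives 0.022. Compound 3 `CC(=O)Nc1cc(-c2ccc(N(C)C(=O)c3c(F)cccc3Cl)c(N3CCCC3)c2)n(C(C)C)n1` gives 0.009. Compound 1 stands lowest of the three; its gap to compound 3, the nearest, and to compound 2, the furthest, both lie beyond the scatter, so compound 1 has the smallest free fraction of the set. No pair among these three differs in only one place, so no single step can be read from them.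

Compound 4 `CC(=O)Nc1cc(-c2ccc(N(C)C(=O)c3c(F)cccc3Cl)c(N3CC4CC4C3)c2)n(CC2CC2)n1` is not yet measured. It differs from compound 1 by cyclopropylmethyl in place of cyclobutyl on an aromatic nitrogen; the two have the same atoms, joined differently. For the measured compounds named here, no measured step shows the effect of such a change, and the rest of the structure is unchanged. The expectation is a step within the scatter, in no particular direction: a 1.5-fold higher number from compound 1 to compound 4 (0.18 log units; within the scatter). For compound 4 the estimate in this assay is 0.0006, with a range from 0.0002 to 0.002.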

Compound 4, unbound fraction: 0.002
For compound 4 the middle estimate is 3.3-fold (0.52 log units) below the measured one, and the stated range covers the measured number.
By their numbers in this assay, from the lowest: compound 1; then compound 4; then compound 3; then compound 2.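

For the compounds shown here, on the aromatic nitrogen of the five-membered aromatic ring with 2 nitrogen, cyclopropylmethyl in place of cyclobutyl gives the first single-place step in this assay (a 5.0-fold higher number from compound 1 to compound 4 (0.70 log units; beyond the scatter)), and that step lies beyond the scatter. The position therefore responds to how the same carbon atoms are joined, not only to which atoms are present, and an exchange of two groups with the same heavy-atom count is enough to move the free fraction. No measured property of either group bears on this step, so it stays without an assigned cause.

The compounds shown leave open how this position would read in this assay with a group carrying an amine or a carboxylic acid, or with a longer chain such as hexyl. Also open, as far as these compounds go, is whether cyclopropylmethyl would give a step of similar size on the core of compound 2 or compound 3.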